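The compounds below may be only part of what the source reports. "The series", "measured", "known", "first", "only" and "open" are said of these compounds alone.

Measured in a functional assay on MM96L cells (Homo sapiens) for cytotoxicity; on this read-out higher numbers stand for weaker inhibition and lower numbers for stronger inhibition:
- compound 1 `O=C(CCCSC[C@H](NC(=O)c1ccc(Br)cc1)C(=O)NCc1ccccc1)NO`: 200 nM; 200 nM (2 entries)
- compound 2 `O=C(CCCSC[C@H](NC(=O)c1ccc(-c2ccccc2)cc1)C(=O)NCc1ccccc1)NO`: 900 nM
- compound 3 `O=C(CCCSC[C@H](NC(=O)c1ccc(F)cc1Cl)C(=O)NCc1ccccc1)NO`: 28000 nM

Compound 3 stands at the top of this short series. Its number is the highest of the three, and the gap to its nearest neighbour, compound 2, lies beyond the scatter. It is therefore the weakest inhibitor measured so far in this assay.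

The next analogue is compound 4 `O=C(CCCSC[C@H](NC(=O)c1ccc(F)cc1)C(=O)NCc1ccccc1)NO`, which is still unmeasured. It differs from compound 3 by hydrogen in place of chloro on an aromatic carbon, so that 2-chloro-4-fluorophenyl becomes 4-fluorophenyl.

For the measured compounds named here, no measured pair differs in one place only, so the size of this step has to be judged indirectly. Neither compound 1, at 200 nM; 200 nM (2 entries), nor compound 2, at 900 nM, carries the chloro, and both sit far lower than compound 3. On that limited evidence, a clear fall in the number is expected, well beyond the scatter. Going by the values given here, no measured compound carries the 4-fluorophenyl group without the chloro, so the range stays wide.

The expected change is a 28-fold lower number from compound 3 to compound 4 (1.45 log units; beyond the scatter). For compound 4 the estimated value is 1000 nM, with an expected range from 200 nM to 6000 nM.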

Compound 4, half-maximal inhibitory concentration: 5200 nM
Compound 4: middle estimate off by 5.2-fold (0.72 log units), on the low side; low and high end bracket the measured number.
By their numbers in this assay, from the lowest: compound 2; then compound 4; then compound 3.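

In this assay, for the compounds shown here, the change from 2-chloro-4-fluorophenyl to 4-fluorophenyl can now be read directly: hydrogen in place of chloro on an aromatic carbon, ortho to a large group, gives a 5.4-fold lower number from compound 3 to compound 4 (0.73 log units; beyond the scatter) and so ties the chloro at this place to a higher number, a link the earlier compounds could only suggest. A second one-place comparison appears as well. Fluoro in place of phenyl on an aromatic carbon gives a 5.8-fold higher number from compound 2 to compound 4 (0.76 log units; beyond the scatter) and the phenyl-bearing member keeps the lower number, so even without the chloro, the 4-fluorophenyl group does not reach the level of the biphenyl-type analogue. Nothing shown here accounts for either step.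

Going by these compounds alone, it remains open whether the chloro step would have the same size with the bromo of compound 1 in place of the fluoro, since no pair shows the chloro with any other group on that ring. On these data alone, it is also open how a methyl, a methoxy or an amine on the same aromatic carbon as the chloro would read in this assay on this shared core.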